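A few compounds are considered here, and "the series" means these few. Any claim that something is new, unique, unknown or untested is made for them only; others in the source may bear on it.

The measured compounds:

Compound 1, `COc1ccc(-n2ccnc2SCC(=O)Nc2ccccc2Br)cc1`, gives in an ADME assay on MT4 cells (Homo sapiens) for cytotoxicity, read by MTT assay (a higher number here means that more compound is tolerated, a lower number that less compound is tolerated), the value > 298000 nM, which is a limit of the assay rather than a number.

Compound 2, `COc1ccc(-n2ccnc2SCC(=O)Nc2ccccc2F)cc1`, gives in this assay the value >= 41900 nM, likewise a limit.

Compound 3, `Cc1ccc(NC(=O)CSc2nccn2-c2ccc(Cl)cc2)c(Br)c1`, gives in this assay the value 221000 nM.

Going by the values given here, compound 3 thus stands as the only real number among the three results. The other two results are limits: the limit of > 298000 nM in this assay, at which 1 of the 3 values shown sits, and (the limit of >= 41900 nM in this assay, at which 1 of the 3 values shown sits). Compound 4, `COc1ccc(-n2ccnc2SCC(=O)Nc2ccc(C)cc2Br)cc1`, is not yet measured. It differs from compound 3 by methoxy in place of chloro on an aromatic carbon. Among the compounds with values here, the only measured step, a step that the two limits leave unreadable from compound 1 to compound 2, concerns a different change and its size cannot be read, so no measured step bears on the change from compound 3 to compound 4. With nothing pointing to a shift in either direction, the expected step of a 1.1-fold lower number from compound 3 to compound 4 (0.04 log units; within the scatter) is none beyond the scatter, though the uncertainty is wide. Compound 4 is therefore estimated to give 200000 nM in this assay, with a range from 60000 nM to 400000 nM.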

Compound 4, half-maximal cytotoxic concentration: 25800 nM
For compound 4 the middle estimate is 7.8-fold (0.89 log units) above the measured one, outside the stated range (below it).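

In this assay, going by these compounds alone, the change from 4-chlorophenyl to 4-methoxyphenyl gives an 8.6-fold lower number from compound 3 to compound 4 (0.93 log units; beyond the scatter); this is the only step here with real numbers at both ends, and it shows that the group at this place on the ring can change how much compound is tolerated. Methyl in place of hydrogen on an aromatic carbon gives an at least 11-fold lower number from compound 1 to compound 4 (1.06 log units; beyond the scatter), and 2-bromo-4-methylphenyl in place of 2-fluorophenyl gives an at least 1.6-fold lower number from compound 2 to compound 4 (0.21 log units; that floor lies within the scatter). Both of these steps start from a limit of the assay rather than a number, so each gives only a minimum size.

Nothing measured here says why the number falls with methoxy at this place. Going by these compounds, how an amine or a carboxylic acid at the same place would compare with chloro and methoxy remains open.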